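Trifluoromethylphenyl Replacing Methoxyphenyl on a Fused Core

The compounds below may be only part of what the source reports. "The series", "measured", "known", "first", "only" and "open" are said of these compounds alone.

The measured compounds, all tested in a functional assay on NCI-H226 cells (Homo sapiens) for inhibition, read by sulforhodamine B assay, with a stated time of 48 h, tested at 10 uM; on this read-out higher numbers stand for more inhibition at the one concentration tested (going by the name of the read-out) and lower numbers for less inhibition:

Compound 1, `Brc1cn2ccnc2c(-c2ccc3ncn(C4CCCCC4)c3c2)n1`, gives 22.5%.
Compound 2, `COc1ccc(-c2cn3ccnc3c(-c3ccc4ncn(C5CCCCC5)c4c3)n2)cc1`, gives 35.9%.
Compound 3, `Fc1ccc(-c2cn3ccnc3c(-c3ccc4ncn(C5CCCCC5)c4c3)n2)cc1`, gives 23.3%.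

Compound 2 stands highest of the three; its nearest neighbour is compound 3, which lies a number 12.6 percentage points lower from compound 2 to compound 3 (beyond the scatter), and compound 1 lies further off, with a number 13.4 percentage points higher from compound 1 to compound 2 (beyond the scatter). Compound 1 and compound 3 lie within the scatter of each other, as a number 0.8 percentage points higher from compound 1 to compound 3 (within the scatter) shows.

Compound 4, `FC(F)(F)c1cccc(-c2cn3ccnc3c(-c3ccc4ncn(C5CCCCC5)c4c3)n2)c1`, has not yet been measured. It differs from compound 2 in one place: 3-(trifluoromethyl)phenyl in place of 4-methoxyphenyl on an aromatic carbon. Among the measured compounds shown here, the step that bears most directly on this change is the one from compound 2 to compound 3, where a fluoro group replaced the methoxy group on the same ring and gave a number 12.6 percentage points lower from compound 2 to compound 3 (beyond the scatter). Since the 3-(trifluoromethyl)phenyl group, like the 4-fluorophenyl group, carries no hydrogen-bond acceptor, compound 4 is expected to fall back toward the values of compound 1 and compound 3, with a step estimated at a number 10.9 percentage points lower from compound 2 to compound 4 (beyond the scatter). Compound 4 is therefore estimated at 25%, with a range from 10% to 42%.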

Compound 4, a percentage reported as inhibition, at one concentration (the size of the read-out at that concentration, not a potency): 1.55%
Compound 4: the middle estimate sits 23.5 percentage points above what was measured; the whole stated range lies above it.
By their numbers in this assay, from the lowest: compound 4; then compounds 1 and 3 (each within the scatter of the next); then compound 2.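

In this assay, this position on the shared core can carry a group that leaves far less inhibition than any earlier compound, with a number 34.4 percentage points lower from compound 2 to compound 4 (beyond the scatter), a number 21.8 percentage points lower from compound 3 to compound 4 (beyond the scatter) and a number 21 percentage points lower from compound 1 to compound 4 (beyond the scatter). The earlier compounds shown here showed an aryl group here either within the scatter of bromo, as 4-fluorophenyl is, or beyond it on the higher side, as 4-methoxyphenyl is, whereas 3-(trifluoromethyl)phenyl falls beyond the scatter on the lower side of bromo. Nothing available explains why this replacement has so large an effect.

The change alters both the group on the phenyl ring and where it sits, so the compounds shown cannot separate the two. On these data alone, a 3-methoxyphenyl or 4-(trifluoromethyl)phenyl group would bear on that question, and how a 4-aminophenyl group would read at this position also remains open.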